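Sulfonylated azaindole series: chloro added to the thiophene

The source may report more compounds than this note shows. Statements on the series, on what has been measured and on what is new or still open speak of the compounds shown alone.

Measured so far:
compound 1 `CN(C)CCn1cc(S(=O)(=O)c2cc(Cl)cc(Cl)c2)c2cccnc21` gives 28 nM
compound 2 `CN(C)CCn1cc(S(=O)(=O)c2cccs2)c2cccnc21` gives 154 nM

In a functional assay on HeLa cells for agonist activity at 5-hydroxytryptamine receptor 6 (Homo sapiens), read by immunoassay (a lower number here means that less compound is needed, a higher number that more compound is needed for the effect), compound 2 stands highest of the two numbers; its nearest neighbour is compound 1, and the step of a 5.5-fold higher number from compound 1 to compound 2 (0.74 log units; beyond the scatter) lies beyond the scatter. Compound 3 `CN(C)CCn1cc(S(=O)(=O)c2ccc(Cl)s2)c2cccnc21` differs from compound 2 by chloro in place of hydrogen on an aromatic carbon. Among the measured compounds shown here, no measured step adds a chloro to this ring; only the step from compound 1 to compound 2, which removed two chloro atoms with the ring they sit on, bears on it, and it was modest. A modest lower number is therefore expected, a 2.6-fold lower number from compound 2 to compound 3 (0.41 log units; beyond the scatter). Compound 3 is estimated at 60 nM, between 20 nM and 180 nM.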

Compound 3, half-maximal effective concentration: 32 nM
For compound 3 the middle estimate is 1.9-fold (0.27 log units) above the measured one; the range from low to high includes it.
By their numbers in this assay, from the lowest: compounds 1 and 3 (each within the scatter of the next); then compound 2.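

In this assay, chloro in place of hydrogen on the aromatic carbon next to the ring sulfur gives a 4.8-fold lower number from compound 2 to compound 3 (0.68 log units; beyond the scatter), so a single atom at this position changes the number beyond the scatter. With a 1.1-fold higher number from compound 1 to compound 3 (0.06 log units; within the scatter), the 5-chlorothiophen-2-yl and 3,5-dichlorophenyl groups cannot be told apart in this assay. Nothing at hand explains the effect of the chloro. Open, from the compounds shown here alone, is whether the step is specific to chloro: a methyl, a methoxy or a nitrile on this carbon would test that. Also open, going by these compounds, is whether chloro on another thiophene carbon gives the same result.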